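Aryl swaps at the saturated ring carbon, Ehrlich cell series

The source may report more compounds than this note shows. Statements on the series, on what has been measured and on what is new or still open speak of the compounds shown alone.

Three analogues sharing one core have been run in a functional assay on Ehrlich cells (Mus musculus) for cytotoxicity; a higher number here means a weaker inhibitor, a lower number a stronger inhibitor. Compound 1 `COc1cc(N2C(N)=C(C#N)C(c3ccc(OC)c4ccccc34)C3=C2CC(C)(C)CC3=O)cc(OC)c1OC` was reported as "not active" (no number reported) in this assay, so it contributes no number. Compound 2 `COc1cc(N2C(N)=C(C#N)C(c3ccc(O)cc3)C3=C2CC(C)(C)CC3=O)cc(OC)c1OC` gives 75800 nM in this assay, and compound 3 `COc1cc(N2C(N)=C(C#N)C(c3ccc(Cl)cc3Cl)C3=C2CC(C)(C)CC3=O)cc(OC)c1OC` gives 94700 nM. Going by the values given here, compound 3 and compound 2 therefore lie within the scatter of each other, as the single one-place step shows: a 1.2-fold higher number from compound 2 to compound 3 (0.10 log units; within the scatter). The only other entry, compound 1, carries no number to compare.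

Compound 4 `COc1cc(N2C(N)=C(C#N)C(c3ccc(C)o3)C3=C2CC(C)(C)CC3=O)cc(OC)c1OC` differs from compound 3 by 5-methylfuran-2-yl in place of 2,4-dichlorophenyl on a saturated ring carbon. Among the compounds with values here, the one measured step that bears on this position is a 1.2-fold higher number from compound 2 to compound 3 (0.10 log units; within the scatter), an exchange of the aryl group at the same saturated ring carbon that left the number within the scatter. Within the data shown here, no measured step covers a five-membered ring with one hetero atom here, so the expectation rests on that single exchange alone. Compound 4 is therefore expected to give 90000 nM, with a range from 40000 nM to 200000 nM. The estimated step of a 1.1-fold lower number from compound 3 to compound 4 (0.02 log units; within the scatter) is expected to stay within the scatter, in no clear direction.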

Compound 4, half-maximal inhibitory concentration: 216000 nM
Compound 4: the middle estimate sits 2.4-fold (0.38 log units) below what was measured, outside the stated range (above it).
By their numbers in this assay, from the lowest: compounds 2 and 3 (each within the scatter of the next); then compound 4.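

In this assay, going by these compounds alone, the exchange for 5-methylfuran-2-yl on the saturated ring carbon gives a 2.3-fold higher number from compound 3 to compound 4 (0.36 log units; beyond the scatter) and a 2.8-fold higher number from compound 2 to compound 4 (0.45 log units; beyond the scatter) and is the first change at this position to pass the scatter. The number here thus responds modestly to the group carried, with compound 2 and compound 3 within the scatter of each other and compound 4 higher than both, while steps involving compound 1 cannot be read. Nothing at hand accounts for this shift.

The compounds shown leave open whether the shift goes with the five-membered ring, its oxygen or its methyl group, as compound 4 brings all three at once. From the compounds shown here alone, how a plain furyl, a thienyl or a pyridyl group would read at this carbon also remains open.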